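This account rests on a few compounds, and the source may have more. Where it says the series, first, only, none or still open, it means among the compounds named here.

Measured so far in an ADME assay on Lu1 cells (Homo sapiens) for cytotoxicity; on this read-out lower numbers stand for an effect already at smaller amounts and higher numbers for an effect only at larger amounts of compound:
compound 1 `CC1=C(C=O)C[C@@H]2[C@@](C)(CCC3=CC(=O)OC3O)[C@H](C)CC[C@@]12C`: 8.7 ug/mL
compound 2 `CC1=CCC[C@@H]2[C@@](C)(/C=C/C3=CC(=O)O[C@H]3O)[C@H](C)CC[C@@]12C`: 2.6 ug/mL
compound 3 `CC1=CCC[C@@H]2[C@@](C)(C[C@H](O)C3=CCOC3=O)[C@H](C)CC[C@@]12C`: 2.9 ug/mL

Compound 3 stands second highest of the three numbers. Its nearest neighbour is compound 2; that gap lies within the scatter, so no order between compound 2 and compound 3 can be read from these numbers. The only gap beyond the scatter is to compound 1, whose number is the higher one of the pair, so compound 1 shows its effect only at larger amounts than compound 3.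

Compound 4 `CC1=CCC[C@@H]2[C@@](C)(C[C@H](O)C3=CC(=O)O[C@H]3O)[C@H](C)CC[C@@]12C` has not yet been measured in this assay. It differs from compound 3 in a single place: a group of 7 heavy atoms (4 carbon, 3 oxygen; one five-membered non-aromatic ring with 1 hetero atom) in place of a group of 6 heavy atoms (4 carbon, 2 oxygen; one five-membered non-aromatic ring with 1 hetero atom), on a saturated chain carbon bound to an oxygen on a saturated carbon and a saturated chain carbon. The entering group is the same ring that compound 2 carries, while the side chain with its hydroxyl is that of compound 3. Among the measured compounds shown here, both parents sit within the scatter of each other, and no step between measured compounds is available to size this change, so no step beyond the scatter is expected in either direction: the step from compound 3 to compound 4 is estimated at a 1.1-fold lower number from compound 3 to compound 4 (0.03 log units; within the scatter). Compound 4 is expected to give about 2.7 ug/mL in this assay, with a range from 1.3 ug/mL to 5.5 ug/mL.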

Compound 4, concentration for half-maximal effect: 2.4 ug/mL
For compound 4 the middle estimate is 1.1-fold (0.05 log units) above the measured one, and the stated range covers the measured number.
By their numbers in this assay, from the lowest: compounds 4, 2 and 3 (each within the scatter of the next); then compound 1.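

In this assay, among the compounds shown here, the exchange on the saturated chain carbon bound to an oxygen on a saturated carbon and a saturated chain carbon gives the first step between compounds that differ in one place: a 1.2-fold lower number from compound 3 to compound 4 (0.08 log units; within the scatter). At this position, the group of 7 heavy atoms, with its 1 hydrogen-bond donor, 3 hydrogen-bond acceptors and 1 defined stereocentre, therefore cannot be told apart in this assay from the group of 6 heavy atoms, with 0 hydrogen-bond donors and 2 hydrogen-bond acceptors, while the rest of the molecule stays the same. No measurement is available that bears on the reason for this result.

The compounds shown leave open whether a different group at this place, such as an open-chain carboxylic acid or an amine in place of the five-membered ring, would give a step beyond the scatter. Also open, as far as these compounds go, is how the opposite configuration at the defined stereocentre of the entering group would read in this assay.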